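Trifluoromethyl for Chloro: Estimating Compound 4

The source may hold more compounds than are shown below. What is called first, only, known or untested is meant among the compounds shown, and "the series" means these compounds.

Measured so far in a functional assay on HL-60 cells (Homo sapiens) for cytotoxicity, read by CCK-8 assay, with a stated time of 72 h; a higher number here means a weaker inhibitor, a lower number a stronger inhibitor:
Compound 1, `COc1ccccc1/C=c1/[nH]c(=O)/c(=C\c2ccccc2OC)n(C)c1=O`, gives 16200 nM.
Compound 2, `C=CCn1c(=O)/c(=C\c2ccccc2Cl)[nH]c(=O)/c1=C\c1ccccc1OC`, gives 4200 nM.
Compound 3, `C=CCn1c(=O)/c(=C\c2ccc(Cl)c(Cl)c2)[nH]c(=O)/c1=C\c1ccccc1OC`, is reported as "not active" (no number reported), with no number given.

Among the two compounds with a number in this assay, compound 2 stands at the lowest value, meaning the stronger inhibition. Its nearest neighbour is compound 1, whose number is higher by a margin that lies beyond the usual scatter of this kind of measurement. Compound 3 carries two chloro groups on one of its aromatic rings and gave no measurable activity at all, so it offers no number to compare.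

Compound 4, `C=CCn1c(=O)/c(=C\c2ccccc2C(F)(F)F)[nH]c(=O)/c1=C\c1ccccc1OC`, is built from compound 2 by one change: trifluoromethyl in place of chloro on an aromatic carbon. For the measured compounds named here, no pair of measured compounds shows this particular exchange, so there is no measured step to lean on. The expectation is that the change from compound 2 to compound 4 produces at most a small shift in this assay, plausibly toward a somewhat higher number, within or only slightly beyond the scatter; the step is estimated as a 1.4-fold higher number from compound 2 to compound 4 (0.15 log units; within the scatter).

Compound 4 is therefore expected to give about 6000 nM in this assay, with a likely range from 2000 nM to 20000 nM.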

Compound 4, half-maximal inhibitory concentration: 4600 nM
For compound 4 the middle estimate is 1.3-fold (0.12 log units) above the measured one; the measured number falls inside the stated range.
By their numbers in this assay, from the lowest: compounds 2 and 4 (each within the scatter of the next); then compound 1.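

In this assay the exchange of chloro for trifluoromethyl, on an aromatic carbon ortho to a large group, gives a 1.1-fold higher number from compound 2 to compound 4 (0.04 log units; within the scatter) and so leaves the reading unchanged within the scatter. For the compounds shown here, this is the first measured step at this place on the ring, and it shows that a group of four heavy atoms can stand where a single chlorine stood without costing measurable activity against these cells. The result therefore shows that the single chlorine is not required here, and that this place tolerates at least one substituent with more heavy atoms, while no information shown here accounts for why the two groups read alike.

Going by these compounds, both groups compared so far count no hydrogen-bond donors and no hydrogen-bond acceptors, so it stays open whether an amine or a carboxylic acid, which bring such atoms to the same carbon, would be accepted as well. On these data alone, it also stays open whether a longer chain would fit there, and whether the same exchange would read alike on other carbons of this ring.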